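The compounds below may be only part of what the source reports. "The series", "measured", "known", "first", "only" and "open" are said of these compounds alone.

In an assay on isolated protein for inhibition of Nicotinamide phosphoribosyltransferase (Homo sapiens), read by fluorescence, with stated times of 5 min and 15 min (a lower number here means a stronger inhibitor, a higher number a weaker inhibitor), compound 2 `Nc1ccccc1NC(=O)c1ccc(NC(=S)NCc2cccnc2)cc1` gives 116 nM, the only number shown in this series. Compound 1 `Nc1ccccc1NC(=O)c1ccc(NC(=S)NCc2ccccc2F)cc1` gives > 2000 nM in this assay, which is a limit of the assay rather than a number (the limit of > 2000 nM in this assay, at which 1 of the 2 values shown sits). Among the compounds with values here, the step of an at least 17-fold lower number from compound 1 to compound 2 (1.23 log units; beyond the scatter) is the only measured step available. Compound 3 `Cc1ccc(CNC(=S)Nc2ccc(C(=O)Nc3ccccc3N)cc2)cn1` differs from compound 2 by methyl in place of hydrogen on an aromatic carbon. Within the data shown here, the measured step exchanged one whole ring for another, so it says little about a methyl added to a ring that is already present, and no measured step bears directly on this change. A step of no more than the usual scatter is therefore expected, in either direction: a 1.0-fold higher number from compound 2 to compound 3 (0.01 log units; within the scatter). Compound 3 is estimated at 120 nM, with a range from 50 nM to 300 nM.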

Compound 3, half-maximal inhibitory concentration: > 2000 nM
Compound 3: a limit, no number; the forecaster's own chance of this, stated with the estimate: 3%; middle value at least 16-fold (1.22 log units) away from the limit.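

In this assay, going from pyridin-3-yl to 6-methylpyridin-3-yl, a single added carbon next to the ring nitrogen, gives an at least 17-fold higher number from compound 2 to compound 3 (1.23 log units; beyond the scatter). The earlier step swapped one whole ring for another; this pair shows that a very small change on the ring of compound 2 can matter as much, and that a ring nitrogen alone does not secure a measurable value. The result for compound 3 is a limit of the assay, not a number, and it is the second compound at that limit: the limit of > 2000 nM in this assay, at which 2 of the 3 values shown sit.

The step between compound 1 and compound 3 cannot be read, as both results are limits. Open too, as far as these compounds go, is whether a fluorine, a methoxy group or an amine at this place would fare like the methyl, and whether a methyl elsewhere on the ring would do the same.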